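Urea-to-amide change on a pyrazole growth inhibitor

This account rests on a few compounds, and the source may have more. Where it says the series, first, only, none or still open, it means among the compounds named here.

Measured compounds:
Compound 1 `COc1cc(-c2nn(-c3cccc(NC(=O)Nc4ccc(Cl)c(Cl)c4)c3)cc2-c2ccncc2)ccc1Cl` gives 697 nM in a functional assay on OVCAR-3 cells (Homo sapiens) for inhibition, read by sulforhodamine B assay, with a stated time of 48 h; on this read-out higher numbers stand for weaker inhibition of growth and lower numbers for stronger inhibition of growth.
Compound 2 `COc1cc(-c2nn(-c3cccc(NC(=O)Nc4cccc(C(F)(F)F)c4)c3)cc2-c2ccncc2)ccc1Cl` gives 579 nM in this assay.

Compound 2 gives the lower of the two numbers in this assay, and the step of a 1.2-fold lower number from compound 1 to compound 2 (0.08 log units; within the scatter) lies within the scatter, so the two compounds cannot be ordered. Compound 3 `COc1cc(-c2nn(-c3cccc(NC(=O)c4ccc(Cl)c(C(F)(F)F)c4)c3)cc2-c2ccncc2)ccc1Cl` differs from compound 2 by 4-chloro-3-(trifluoromethyl)phenyl in place of (3-(trifluoromethyl)phenyl)amino on a carbonyl carbon. Among the compounds with values here, no measured step bears on this change: the one step on record, a 1.2-fold lower number from compound 1 to compound 2 (0.08 log units; within the scatter), alters only the terminal aryl, not the urea linkage itself. Compound 3 is therefore expected to give a number close to that of compound 2, with a 1.2-fold higher number from compound 2 to compound 3 (0.08 log units; within the scatter) as the estimated step. The estimate for compound 3 is 700 nM, in the range 250 nM to 2000 nM.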

Compound 3, concentration for 50% growth inhibition: 2420 nM
Estimate against measurement, compound 3: 3.5-fold (0.54 log units) below, outside the stated range (above it).
By their numbers in this assay, from the lowest: compounds 2 and 1 (each within the scatter of the next); then compound 3.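

In this assay, within the data shown here, the change at this carbonyl carbon is the first to move the number beyond the scatter, with a 4.2-fold higher number from compound 2 to compound 3 (0.62 log units; beyond the scatter) and a 3.5-fold higher number from compound 1 to compound 3 (0.54 log units; beyond the scatter), both toward weaker inhibition of growth. This change removes the amino nitrogen with its hydrogen-bond donor and brings in a chlorine at the same time, so the two cannot be separated. Nothing measured here explains the result. The compounds shown leave open which of the two accounts for the step, and what a 3-(trifluoromethyl)phenyl on the carbonyl carbon, without the chlorine, or a methylene in place of the amino nitrogen would give.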